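Removing a Chloro Group from a Weak Lipoxygenase Inhibitor Series

This account rests on a few compounds, and the source may have more. Where it says the series, first, only, none or still open, it means among the compounds named here.

Measured compounds:
Compound 1 `N#Cc1ccn2c(-c3ccccc3)c(-c3ccccc3)c(Cc3ccccc3)c2c1`: 46000 nM
Compound 2 `Cc1ccc(S(=O)(=O)Oc2c(-c3ccccc3)c(-c3ccccc3)n3ccc(C#N)cc23)cc1`: 25000 nM
Compound 3 `N#Cc1ccn2c(-c3ccccc3)c(-c3ccccc3)c(C(O)c3ccc(Cl)cc3)c2c1`: "not determined" (no result reported)

Three compounds share one core and were tested in an assay for inhibition of Polyunsaturated fatty acid lipoxygenase ALOX15 (Oryctolagus cuniculus); on this read-out higher numbers stand for weaker inhibition and lower numbers for stronger inhibition. Compound 1 gives 46000 nM. Compound 2 carries a ((4-methylphenyl)sulfonyl)oxy group in place of the benzyl group of compound 1; in this assay compound 2 gives 25000 nM. The step between them, a 1.8-fold lower number from compound 1 to compound 2 (0.26 log units; within the scatter), is within the scatter, so both compounds count as weak inhibitors of about the same strength. Compound 3 carries a (4-chlorophenyl)(hydroxy)methyl group on the core, but in this assay compound 3 gives "not determined" (no result reported), so it stands nowhere on the measured scale.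

Compound 4 `N#Cc1ccn2c(-c3ccccc3)c(-c3ccccc3)c(C(O)c3ccccc3)c2c1` differs from compound 3 by hydrogen in place of chloro on an aromatic carbon, which one bond further out reads 4-chlorophenyl to phenyl. Within the data shown here, the only measured step, a 1.8-fold lower number from compound 1 to compound 2 (0.26 log units; within the scatter), concerns a different position on the core and does not bear on this change; no measured step sets an expected size or direction for it. The two measured values are the only anchor, so compound 4 is estimated at 35000 nM, expected to fall between 8000 nM and 150000 nM.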

Compound 4, half-maximal inhibitory concentration: 48000 nM
For compound 4 the middle estimate is 1.4-fold (0.14 log units) below the measured one; the measured number falls inside the stated range.
By their numbers in this assay, from the lowest: compounds 2, 1 and 4 (each within the scatter of the next).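

Compound 3 has no number, so the step from compound 3 to compound 4 cannot be read and the removal of the chloro group has no measured size. Among these compounds, compound 4 instead gives a first look at the carbon linking the phenyl group to the shared core: in this assay, hydroxy in place of hydrogen on that carbon gives a 1.0-fold higher number from compound 1 to compound 4 (0.02 log units; within the scatter), and hydroxy(phenyl)methyl in place of ((4-methylphenyl)sulfonyl)oxy gives a 1.9-fold higher number from compound 2 to compound 4 (0.28 log units; within the scatter), so neither change separates the compounds. No available evidence accounts for these closely matched numbers.

On these data alone, whether an amine or a carboxylic acid on the aromatic carbon that held the chloro group would move the number beyond the scatter remains open. So does whether a longer chain in place of hydroxy(phenyl)methyl would do so.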